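Replacing a hydroxypropyl chain with a larger sulfur-bearing group

The source may report more compounds than this note shows. Statements on the series, on what has been measured and on what is new or still open speak of the compounds shown alone.

Compound 2 `O=c1cc(Cn2cc(CCCCO)nn2)c2ccc(O)cc2o1` carries a 4-hydroxybutyl chain on the shared core. In a functional assay on HepG2 cells (Homo sapiens) for inhibition, read by MTT assay, with a stated time of 72 h (a higher number here means a weaker inhibitor, a lower number a stronger inhibitor), compound 2 gives > 100000 nM, which is a limit of the assay rather than a number. Within the data shown here, its only measured neighbour, compound 1 `CC(O)c1cn(Cc2cc(=O)oc3cc(O)ccc23)nn1`, carries a 1-hydroxyethyl group in the same position. In this assay compound 1 gives > 100000 nM, again a limit. Among the measured compounds shown here, the one measured step, a step that the two limits leave unreadable from compound 1 to compound 2, therefore cannot be read, since (the limit of > 100000 nM in this assay, at which 2 of the 2 values shown sit). Compound 3 `O=c1cc(Cn2cc(CSC(=S)N3CCOCC3)nn2)c2ccc(O)cc2o1` differs from compound 2 in a group of 9 heavy atoms (5 carbon, 1 nitrogen, 1 oxygen, 2 sulfur; one six-membered non-aromatic ring with 2 hetero atoms) in place of a group of 4 heavy atoms (3 carbon, 1 oxygen; no ring), on a saturated chain carbon bound to an aromatic carbon. For the measured compounds named here, no measured step touches this kind of change, so any expectation rests only on the fact that both measured compounds sit at the limit. For compound 3 the expected result in this assay is 100000 nM, within a range from 20000 nM to 300000 nM, and it is likely that only a limit will again be reported. The step of a number no higher from compound 2 to compound 3 (the limit leaves the size open) is thus expected to be small, with no direction supported beyond the scatter.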

Compound 3, half-maximal inhibitory concentration: 99400 nM
The estimate for compound 3 lay 1.0-fold (0.00 log units) above the measured number; the measured number falls inside the stated range.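

In this assay compound 3, which carries a group of 9 heavy atoms with a six-membered non-aromatic ring and two sulfur atoms on a saturated chain carbon bound to an aromatic carbon, gives 99400 nM, the first result in this series that is an actual number. Compound 2 gives > 100000 nM, which is a limit of the assay and not a number. That leaves a number no higher from compound 2 to compound 3 (the limit leaves the size open), and neither this step nor the earlier one can be read in size, because both run into the same limit: the limit of > 100000 nM in this assay, at which 2 of the 3 values shown sit.

On these data alone, a single number so close to the limit shows no trend, so it remains open whether any change at this position can give a clearly stronger inhibitor in this assay. It is also unknown which part of the new group matters, and an amine, a carboxylic acid or a sulfur-bearing chain without the ring at the same place would be needed to separate the contribution of the ring from that of the sulfur atoms.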